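A few compounds are considered here, and "the series" means these few. Any claim that something is new, unique, unknown or untested is made for them only; others in the source may bear on it.

Working notes on the series.

Three compounds share one core and differ only in the chain on the sulfonyl group. In an ADME assay on microsomes from liver (Rattus norvegicus) for metabolic stability, with a stated time of 10 min (on this read-out higher numbers stand for a more stable compound and lower numbers for a less stable compound), compound 3 `CC(C)(C)CNCCS(=O)(=O)NC(=O)c1ccc(Nc2nc(NC3(c4ccc(Cl)cc4)CC3)nc(OCC(F)(F)F)n2)cc1` gives 90%, the highest of the three numbers, though within the scatter of both others. Compound 2 `CCS(=O)(=O)NC(=O)c1ccc(Nc2nc(NC3(c4ccc(Cl)cc4)CC3)nc(OCC(F)(F)F)n2)cc1` gives 85% in this assay, and the step of a number 5 percentage points higher from compound 2 to compound 3 (within the scatter). Compound 1 `CC(C)C(=O)NCCS(=O)(=O)NC(=O)c1ccc(Nc2nc(NC3(c4ccc(Cl)cc4)CC3)nc(OCC(F)(F)F)n2)cc1` gives 84%, with the step of a number 6 percentage points higher from compound 1 to compound 3 (within the scatter); the remaining pair shows a number 1 percentage points higher from compound 1 to compound 2 (within the scatter).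

Compound 4 `CS(=O)(=O)NC(=O)c1ccc(Nc2nc(NC3(c4ccc(Cl)cc4)CC3)nc(OCC(F)(F)F)n2)cc1` is not yet measured. Its change from compound 3 reads (hydrogen in place of (neopentylamino)methyl on a saturated chain carbon bound to a sulfonyl sulfur). The bearing steps are the one adding neopentylamino to the chain, compound 2 to compound 3, and the one removing (isopropylcarbonyl)amino from the same chain position, compound 1 to compound 2; both stayed within the scatter, as did the third step. For the measured compounds named here, the present change cuts one bond further in than either of them, leaving a methylsulfonyl group, and no measured step covers such a shortening directly. Still, every change at this chain so far has left the read-out essentially flat.

For compound 4 the expected step is a number 5 percentage points lower from compound 3 to compound 4 (within the scatter), none beyond the scatter. Compound 4 is therefore estimated at 85%, with a range from 72% to 94%.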

Compound 4, percent of the compound remaining: 85%
Estimate against measurement, compound 4: no gap at the digits printed, within the range that was stated.
By their numbers in this assay, from the lowest: compounds 1, 2, 4 and 3 (each within the scatter of the next).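

Working notes, continued.

The cut back to a methylsulfonyl group, with hydrogen in place of (neopentylamino)methyl on a saturated chain carbon bound to a sulfonyl sulfur, is now covered directly in this assay, with a number 5 percentage points lower from compound 3 to compound 4 (within the scatter) as the step for loss of the whole amine arm. The same position gives no change at the digits printed from compound 2 to compound 4 (within the scatter) when hydrogen replaces methyl and a number 1 percentage points higher from compound 1 to compound 4 (within the scatter) when hydrogen replaces ((isopropylcarbonyl)amino)methyl, so across these four compounds, with none going against it, the read-out shows no step beyond the scatter whether the chain ends in a secondary amine, an amide or nothing more than a methyl group. No measurement of any other kind speaks to why this position stays flat.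

Still open, from the compounds shown here alone, is whether a carboxylic acid or a phenyl ring at the end of the chain, or a chain longer than any of these, would also stay within the scatter in this assay as the compounds here do. All four compounds carry the same core, so they say nothing on how the read-out responds to a change outside the chain on the sulfonyl group.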